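This account rests on a few compounds, and the source may have more. Where it says the series, first, only, none or still open, it means among the compounds named here.

Working notes on the series.

In a functional assay on NIH3T3 cells (Mus musculus) (on this read-out lower numbers stand for an effect already at smaller amounts and higher numbers for an effect only at larger amounts of compound), compound 2 `COC(=O)[C@H](CCSC)NC(=O)c1ccc(NCc2cncn2Cc2ccccc2Cl)cc1-c1ccccc1` gives > 10 uM, which is a limit of the assay and not a number. Within the data shown here, compound 1 `COC(=O)[C@H](CCSC)NC(=O)c1ccc(NCc2cncn2Cc2ccccc2C#N)cc1-c1ccccc1`, the only other member measured, is also at a limit there, giving > 10 uM in this assay. Among the measured compounds shown here, the one step among measured compounds, a step that the two limits leave unreadable from compound 1 to compound 2, is therefore unreadable in size (the limit of > 10 uM in this assay, at which 2 of the 2 values shown sit). Compound 3 `COC(=O)[C@H](CCSC)NC(=O)c1ccc(NCc2cncn2Cc2ccc(-c3ccccc3)cc2)cc1-c1ccccc1` is not yet measured; it carries 4-phenylphenyl in place of 2-chlorophenyl on a saturated chain carbon bound to an aromatic nitrogen. For the measured compounds named here, no measured step bears on this change, so no direction is expected from the data. The estimate for compound 3 in this assay is 12 uM, within 3 uM to 50 uM, meaning an expected step that the limit leaves unreadable from compound 2 to compound 3.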

Compound 3, concentration for half-maximal effect: > 10 uM
Compound 3 ended at the assay's limit; the forecaster's own chance of this, stated with the estimate: 65%; the middle value is on the limit's open side.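

Among these compounds, compound 3 also sits at a limit of this assay, so no step among compound 1, compound 2 and compound 3 can be read: the limit of > 10 uM in this assay, at which 3 of the 3 values shown sit. The compounds shown leave open whether any group on the saturated chain carbon bound to an aromatic nitrogen gives a readable value in this assay.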